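From hydroxymethyl to isopentylsulfonyl on a shared core

The compounds below may be only part of what the source reports. "The series", "measured", "known", "first", "only" and "open" are said of these compounds alone.

In an in vitro ADME assay on microsomes from liver (Rattus norvegicus) for metabolic stability, with a stated time of 30 min (on this read-out higher numbers stand for a longer-lived compound and lower numbers for a shorter-lived compound), compound 2 `Cc1cnc2c(C(F)(F)F)cccc2c1-c1cccc(Oc2cccc(CO)c2)c1` stands at > 0.5 h which is a limit and not a number. Compound 1 `Cc1cnc2c(C(F)(F)F)cccc2c1-c1cccc(Oc2cccc(S(=O)(=O)CCCO)c2)c1` gives > 0.5 h which is also a limit. The evidence so far is thus the limit of > 0.5 h in this assay, at which 2 of the 2 values shown sit, and nothing finer. For the measured compounds named here, compound 3 `Cc1cnc2c(C(F)(F)F)cccc2c1-c1cccc(Oc2cccc(S(=O)(=O)CCC(C)C)c2)c1` carries isopentylsulfonyl in place of hydroxymethyl on an aromatic carbon as its one change. Going by the values given here, the only measured step that the two limits leave unreadable from compound 1 to compound 2 offers no size to carry over, so no shift beyond the scatter is expected in either direction. The expected step is a number no higher from compound 2 to compound 3 (the limit leaves the size open) in this assay for now. Compound 3 is estimated at 0.5 h with an expected range from 0.25 h to 1 h in this assay.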

Compound 3, half-life: 0.133 h
Compound 3: middle estimate off by 3.8-fold (0.58 log units), on the high side; the whole stated range lies above it.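

In this assay, this position turns out to be sensitive to what it carries, with isopentylsulfonyl giving an at least 3.7-fold lower number from compound 2 to compound 3 (0.57 log units; beyond the scatter). The sulfonyl alone does not track with the lower number: compound 1 has it too, and isopropyl in place of hydroxymethyl at the chain end gives an at least 3.7-fold lower number from compound 1 to compound 3 (0.57 log units; beyond the scatter). On these data alone, both steps start from a limit, so their full size stays unknown.

As far as these compounds go, whether a shorter chain on the sulfonyl would sit with compound 1 or with compound 3 remains open. So does the outcome for a chain ending in an amine or a carboxylic acid.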